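The source may hold more compounds than are shown below. What is called first, only, known or untested is meant among the compounds shown, and "the series" means these compounds.

In a functional assay on Jurkat cells (Homo sapiens) for antiproliferative activity, read by MTT assay, with a stated time of 72 h (on this read-out higher numbers stand for weaker inhibition and lower numbers for stronger inhibition), compound 1 (`COc1cc(-n2ncnc2-c2ccc(C)cc2)cc(OC)c1OC`) gives 300 nM. On these data alone, compound 2 (`COc1ccccc1-c1ncnn1-c1cc(OC)c(OC)c(OC)c1`) reaches only a limit of the assay, > 10000 nM, so its true position is unknown. Compound 3 (`COc1cc(-n2ncnc2-c2ccc(SC)cc2)cc(OC)c1OC`) has 4-(methylsulfanyl)phenyl in place of 2-methoxyphenyl on an aromatic carbon. Going by the values given here, the only measured step that bears on this change is the large at least 33-fold higher number from compound 1 to compound 2 (1.52 log units; beyond the scatter), which replaced 4-methylphenyl with 2-methoxyphenyl. Removing 2-methoxyphenyl is therefore expected to reverse much of that loss, giving a large drop in this assay. The expected change is an at least 40-fold lower number from compound 2 to compound 3 (1.60 log units; beyond the scatter). For compound 3 the estimated value is 250 nM, within an expected range of 40 nM to 1500 nM.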

Compound 3, half-maximal inhibitory concentration: 50 nM
Estimate against measurement, compound 3: 5.0-fold (0.70 log units) above; measured number inside the range.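

In this assay, 4-(methylsulfanyl)phenyl at this position gives an at least 200-fold lower number from compound 2 to compound 3 (2.30 log units; beyond the scatter). The size of that step is open-ended, as compound 2 stands at a limit of the assay: the limit of > 10000 nM in this assay, at which 1 of the 3 values shown sits.

Methylsulfanyl in place of methyl gives a 6.0-fold lower number from compound 1 to compound 3 (0.78 log units; beyond the scatter), so 4-methylphenyl and 4-(methylsulfanyl)phenyl are not interchangeable here.

On these data alone, whether the loss with 2-methoxyphenyl follows the methoxy group itself or its place on the phenyl stays open, and 4-methoxyphenyl would separate the two. As far as these compounds go, how a longer chain on the sulfur, such as ethylsulfanyl, compares also stays open.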